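The source may hold more compounds than are shown below. What is called first, only, known or untested is meant among the compounds shown, and "the series" means these compounds.

Three ureas sharing one core have been measured in an assay on microsomes from intestine for inhibition of acyl-CoA:cholesterol acyltransferase (Oryctolagus cuniculus); a lower number here means a stronger inhibitor, a higher number a weaker inhibitor. Compound 1 `CCCCCCN1NN=C(NC(=O)Nc2c(C(C)C)cccc2C(C)C)N1` gives 73 nM, compound 2 `CCCCCCCCCN1NN=C(NC(=O)Nc2c(C(C)C)cccc2C(C)C)N1` gives 31 nM, and compound 3 `CCCCCCCCCCCCCCN1NN=C(NC(=O)Nc2c(C(C)C)cccc2C(C)C)N1` gives 12 nM. Compound 3 thus carries the lowest number of the three, separated from its nearest neighbour by a 2.6-fold lower number from compound 2 to compound 3 (0.41 log units; beyond the scatter) and from the furthest by a 6.1-fold lower number from compound 1 to compound 3 (0.78 log units; beyond the scatter). Compound 4 `CCCCCCCCCCCCCCCCN1NN=C(NC(=O)Nc2c(C(C)C)cccc2C(C)C)N1` takes this series one stage further: ethyl in place of hydrogen on a saturated chain carbon, ten or more bonds along the chain from an amine nitrogen in a ring.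

The measured steps all lengthen the same chain. Replacing hydrogen with propyl gave a 2.4-fold lower number from compound 1 to compound 2 (0.37 log units; beyond the scatter), and the longer pentyl addition gave a 2.6-fold lower number from compound 2 to compound 3 (0.41 log units; beyond the scatter), so the gain per added carbon has grown smaller as the chain has lengthened. A further ethyl is a shorter addition than either, so only a small step, close to the scatter, is expected in this assay. Compound 4 is therefore expected to show a lowering of about a 1.3-fold lower number from compound 3 to compound 4 (0.12 log units; within the scatter), with a value estimated at 9 nM, within a range of 4 nM to 20 nM.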

Compound 4, half-maximal inhibitory concentration: 57 nM
Compound 4: middle estimate off by 6.3-fold (0.80 log units), on the low side; measured number outside the range, above it.
By their numbers in this assay, from the lowest: compound 3; then compounds 2, 4 and 1 (each within the scatter of the next, the first and the last beyond it).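

In this assay, lengthening this chain does not keep lowering the number: the ethyl addition produces a 4.8-fold higher number from compound 3 to compound 4 (0.68 log units; beyond the scatter). The lowering seen from compound 1 through compound 2 to compound 3 therefore does not extend to compound 4, which goes against it and stands level with the shorter chains, with a 1.8-fold higher number from compound 2 to compound 4 (0.26 log units; within the scatter) and a 1.3-fold lower number from compound 1 to compound 4 (0.11 log units; within the scatter). No evidence is available here to explain this reversal.

Where a pentadecyl chain would fall remains open, and with it the exact length at which the number turns upward. Also open, on these data alone, is whether a branched chain, or a chain ending in a carboxylic acid, would keep the low number of compound 3.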